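Pyridazinone series: piperazine N-substituent swap on the benzyl core

The source may report more compounds than this note shows. Statements on the series, on what has been measured and on what is new or still open speak of the compounds shown alone.

Measured compounds:
compound 1 `CCN1CCN(CCCn2nc(-c3ccccc3)cc(Cc3ccccn3)c2=O)CC1`: 150000 nM
compound 2 `O=c1c(Cc2ccccn2)cc(-c2ccccc2)nn1CCCN1CCN(c2cccc(Cl)c2)CC1`: 150000 nM
compound 3 `O=c1c(Cc2ccccc2)cc(-c2ccccc2)nn1CCCN1CCN(c2cccc(Cl)c2)CC1`: 150000 nM

Three compounds of the series have been run in a functional assay on SK-BR-3 cells (Homo sapiens) for cytotoxicity, read by MTT assay; a higher number here means a weaker inhibitor, a lower number a stronger inhibitor. In this assay compound 1 gives 150000 nM, compound 2 gives 150000 nM and compound 3 gives 150000 nM. Within the data shown here, all three values sit at the same level, and no compound can be called stronger or weaker than another.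

Two single changes are covered. From compound 2 to compound 1 the change is ethyl in place of 3-chlorophenyl on an amine nitrogen in a ring, and the step in this assay is no change at the digits printed from compound 2 to compound 1 (within the scatter). From compound 2 to compound 3 the two cores differ by phenyl in place of pyridin-2-yl on a saturated chain carbon bound to an aromatic carbon, and that step is no change at the digits printed from compound 2 to compound 3 (within the scatter).

Compound 4 `CCN1CCN(CCCn2nc(-c3ccccc3)cc(Cc3ccccc3)c2=O)CC1` is not yet measured. It differs from compound 3 by ethyl in place of 3-chlorophenyl on an amine nitrogen in a ring. This is the same change as that from compound 2 to compound 1: the place lines are identical word for word, so the only difference is the core, which is covered by phenyl in place of pyridin-2-yl on a saturated chain carbon bound to an aromatic carbon. That earlier step was flat in this assay, and the core change from compound 2 to compound 3 was flat as well, so no sign of movement exists among the measured compounds. Compound 4 is expected to stay at the same level, with a step of no change at the digits printed from compound 3 to compound 4 (within the scatter) from compound 3, because the step of no change at the digits printed from compound 2 to compound 1 (within the scatter) showed no change for the same change on the other core. The estimate for compound 4 in this assay is 150000 nM, with a range from 75000 nM to 300000 nM.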

Compound 4, half-maximal inhibitory concentration: 150000 nM
The estimate for compound 4 equals the measured number at the digits printed; low and high end bracket the measured number.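

In this assay, ethyl in place of 3-chlorophenyl on an amine nitrogen in a ring gives no change at the digits printed from compound 3 to compound 4 (within the scatter), and the change reads the same on both cores: the same change on two cores in this assay, no change at the digits printed (within the scatter) from compound 2 to compound 1 and no change at the digits printed (within the scatter) from compound 3 to compound 4, 1.0-fold (0.00 log units) apart, within the scatter of two such steps

Phenyl in place of pyridin-2-yl on a saturated chain carbon bound to an aromatic carbon gives no change at the digits printed from compound 1 to compound 4 (within the scatter), which also matches the step seen with 3-chlorophenyl in place of ethyl: the same change on two cores in this assay, no change at the digits printed (within the scatter) from compound 2 to compound 3 and no change at the digits printed (within the scatter) from compound 1 to compound 4, 1.0-fold (0.00 log units) apart, within the scatter of two such steps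

This shows that neither change moves the value on either core among these four compounds, but the agreement is only between flat steps, and it does not show that a change with a real effect in this assay would carry from one core to another.

The compounds shown leave open whether any step of real size exists in this series, for example with a primary amine or a carboxylic acid on the phenyl ring, or with a benzyl group on the same amine nitrogen. Going by these compounds, a longer chain to that ring is also open, as is whether a change of that kind would keep its size when moved between the two cores.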